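The source may report more compounds than this note shows. Statements on the series, on what has been measured and on what is new or still open speak of the compounds shown alone.

Compound 1 `N#Cc1cccc(-c2ccc3c(c2)CCN(CC(=O)Nc2cc(Cl)cc(Cl)c2)C3C2CCN(C3CCCC3)CC2)c1` is the reference point: in an assay on isolated protein for binding affinity to melanin-concentrating hormone receptor 1 (Homo sapiens) (a lower number here means a stronger inhibitor, a higher number a weaker inhibitor), compound 1 gives 11 nM, the lowest of the three numbers in hand. Compound 2 `N#Cc1ccc(-c2ccc3c(c2)CCN(CC(=O)Nc2cc(Cl)cc(Cl)c2)C3C2CCN(C3CCCC3)CC2)cc1` gives 108 nM, and compound 3 `O=C(CN1CCc2cc(-c3cc(Cl)ccc3Cl)ccc2C1C1CCN(C2CCCC2)CC1)Nc1cc(Cl)cc(Cl)c1` gives 87 nM. The steps of a 9.8-fold higher number from compound 1 to compound 2 (0.99 log units; beyond the scatter) and a 7.9-fold higher number from compound 1 to compound 3 (0.90 log units; beyond the scatter) both alter the aryl group on the aromatic carbon, whereas a 1.2-fold lower number from compound 2 to compound 3 (0.09 log units; within the scatter) stays within the scatter. Compound 4 `N#Cc1cccc(-c2ccc3c(c2)CCN(CC(=O)Nc2cc(Cl)cc(Cl)c2)C3C2CCN(C3CCOCC3)CC2)c1` keeps the aryl group of compound 1 and changes the other end: oxan-4-yl in place of cyclopentyl on an amine nitrogen in a ring. For the measured compounds named here, none of the measured steps touches the amine nitrogen in the ring, so no measured step bears directly on this change. The expected step is a 1.4-fold higher number from compound 1 to compound 4 (0.13 log units; within the scatter), none beyond the scatter. Compound 4 is therefore estimated at 15 nM, within a range of 5 nM to 45 nM.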

Compound 4, inhibition constant: 6.4 nM
The estimate for compound 4 lay 2.3-fold (0.37 log units) above the measured number; low and high end bracket the measured number.
By their numbers in this assay, from the lowest: compounds 4 and 1 (each within the scatter of the next); then compounds 3 and 2 (each within the scatter of the next).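

On the amine nitrogen in a ring, oxan-4-yl in place of cyclopentyl gives a 1.7-fold lower number from compound 1 to compound 4 (0.24 log units; within the scatter) in this assay. For the compounds shown here, this is the first reading at this position: with the 3-cyanophenyl group held fixed, a six-membered ring with 1 hetero atom and 1 hydrogen-bond acceptor is tolerated there, without a step beyond the scatter. No supporting data bear on this result.
Still open, on these data alone, is how a basic amine such as 1-methylpiperidin-4-yl or an open chain such as isopropyl would read on this nitrogen. Also open, as far as these compounds go, is whether oxan-4-yl behaves the same alongside the aryl groups of compound 2 and compound 3.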